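Swapping a hydroxy for piperidine on the side chain

This account rests on a few compounds, and the source may have more. Where it says the series, first, only, none or still open, it means among the compounds named here.

Measured so far, in a functional assay on OVCAR-8 cells (Homo sapiens) for antiproliferative activity; on this read-out lower numbers stand for stronger inhibition and higher numbers for weaker inhibition:
- compound 1, `Cn1ncc(Cl)c1-c1cc(C(=O)N[C@@H]2CN[C@H](CCn3cncn3)C[C@H]2c2ccc(Cl)c(Cl)c2)oc1Cl`: 1560 nM
- compound 2, `Cn1ncc(Cl)c1-c1cc(C(=O)N[C@@H]2CN[C@H](CC(=O)NCC(O)CO)C[C@H]2c2ccc(Cl)c(Cl)c2)oc1Cl`: 5900 nM
- compound 3, `Cn1ncc(Cl)c1-c1cc(C(=O)N[C@@H]2CN[C@H](CCO)C[C@H]2c2ccc(Cl)c(Cl)c2)oc1Cl`: 610 nM

Compound 3 gives the lowest number of the three. Its step from compound 1 is a 2.6-fold lower number from compound 1 to compound 3 (0.41 log units; beyond the scatter), and its step from compound 2 is a 9.7-fold lower number from compound 2 to compound 3 (0.99 log units; beyond the scatter), so on these numbers compound 3 is the most potent of the set.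

Compound 4 is `Cn1ncc(Cl)c1-c1cc(C(=O)N[C@@H]2CN[C@H](CCN3CCCCC3)C[C@H]2c2ccc(Cl)c(Cl)c2)oc1Cl`. It differs from compound 3 in one place: piperidin-1-yl in place of hydroxy on a saturated chain carbon, two bonds along the chain from a saturated ring carbon.

For the measured compounds named here, the step that bears most directly on this change is the one between compound 1 and compound 3, a 2.6-fold lower number from compound 1 to compound 3 (0.41 log units; beyond the scatter), where a ring-bearing group at the same place gave way to hydroxy and the number fell. The step from compound 1 to compound 2, a 3.8-fold higher number from compound 1 to compound 2 (0.58 log units; beyond the scatter), shows that a bulkier chain end can push the number up further. Reading the first of these steps backwards, a ring entering where the hydroxy stood is expected to raise the number by a modest amount, with real uncertainty since no measured compound carries piperidine.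

Compound 4 is therefore expected to give about 1400 nM in this assay, within a range from 400 nM to 4500 nM, a step of a 2.3-fold higher number from compound 3 to compound 4 (0.36 log units; beyond the scatter).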

Compound 4, half-maximal inhibitory concentration: 1660 nM
Compound 4: middle estimate off by 1.2-fold (0.07 log units), on the low side; the measured number falls inside the stated range.
By their numbers in this assay, from the lowest: compound 3; then compounds 1 and 4 (each within the scatter of the next); then compound 2.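

In this assay, putting piperidin-1-yl where the hydroxy stood gives a measured step (a 2.7-fold higher number from compound 3 to compound 4 (0.43 log units; beyond the scatter)), so this place on the side chain accepts a six-membered non-aromatic ring, while compound 3, with its hydroxy, keeps the lowest number of the set. The two ring-bearing chain ends cannot be told apart (a 1.1-fold higher number from compound 1 to compound 4 (0.03 log units; within the scatter)): exchanging 1H-1,2,4-triazol-1-yl for piperidin-1-yl changes nothing beyond the scatter, and in these two compounds the number depends little on which of the two rings sits there. A hydroxy on the side chain does not by itself give a low number: compound 2 carries hydroxy groups on its chain end, yet compound 4, with none, gives the lower number (a 3.6-fold lower number from compound 2 to compound 4 (0.55 log units; beyond the scatter)).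

As far as these compounds go, it remains open whether a primary amine, a carboxylic acid or a longer chain ending in hydroxy at this place would fall near compound 3 or near compound 4. Nothing measured on these compounds accounts for the differences in their numbers.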